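Amide for amine on the ring nitrogen of compound 2

This account rests on a few compounds, and the source may have more. Where it says the series, first, only, none or still open, it means among the compounds named here.

Measured so far in a functional assay on PC-3 cells (Homo sapiens) for antiproliferative activity, read by sulforhodamine B assay, with a stated time of 72 h; a higher number here means a weaker inhibitor, a lower number a stronger inhibitor:
compound 1 `CCNc1cnc2ccc(-c3cnc(OC)c(NS(=O)(=O)c4ccc(F)cc4F)c3)cc2c1OC`, 4820 nM
compound 2 `COc1ncc(-c2ccc3ncc(NCc4ccc(C(F)(F)F)cc4)c(OC)c3c2)cc1NS(=O)(=O)c1ccc(F)cc1F`, 2880 nM
compound 3 `COc1ncc(-c2ccc3ncc(NCC4CCN(C(C)=O)CC4)c(OC)c3c2)cc1NS(=O)(=O)c1ccc(F)cc1F`, 2570 nM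

All three share one core and differ only in the group on the nitrogen on the aromatic ring. Compound 2 sits within the scatter of both neighbours: a 1.7-fold lower number from compound 1 to compound 2 (0.22 log units; within the scatter) and a 1.1-fold lower number from compound 2 to compound 3 (0.05 log units; within the scatter), and the remaining pair gives a 1.9-fold lower number from compound 1 to compound 3 (0.27 log units; within the scatter). None of the three changes at this position moved this assay beyond its scatter.

Compound 4 `COc1ncc(-c2ccc3ncc(NC(=O)CN4CCCC(O)C4)c(OC)c3c2)cc1NS(=O)(=O)c1ccc(F)cc1F` takes the next step from compound 2: ((3-hydroxypiperidin-1-yl)methyl)carbonyl in place of 4-(trifluoromethyl)benzyl on a nitrogen on an aromatic ring. Going by the values given here, the measured steps all swapped one group on a saturated chain carbon bound to that nitrogen; here the carbon bearing the nitrogen becomes a carbonyl, which no measured pair covers. Given that the three measured changes at this site stayed within the scatter, the expected step of a 1.0-fold higher number from compound 2 to compound 4 (0.02 log units; within the scatter) is none beyond the scatter, with wider uncertainty than for the measured pairs. Compound 4 is therefore estimated at 3000 nM, in the range 900 nM to 10000 nM.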

Compound 4, half-maximal inhibitory concentration: 1340 nM
Estimate against measurement, compound 4: 2.2-fold (0.35 log units) above; the measured number falls inside the stated range.
By their numbers in this assay, from the lowest: compounds 4, 3, 2 and 1 (each within the scatter of the next, the first and the last beyond it).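

In this assay, going by these compounds alone, the amide on this nitrogen gives the first changes at the position that pass the scatter, both of them modest (a 2.1-fold lower number from compound 2 to compound 4 (0.33 log units; beyond the scatter)) and (a 3.6-fold lower number from compound 1 to compound 4 (0.56 log units; beyond the scatter)). Compound 4 is not separated from the other compound carrying a six-membered non-aromatic ring (a 1.9-fold lower number from compound 3 to compound 4 (0.28 log units; within the scatter)), so the position has so far shown only a shallow response, with a difference only between compound 4 and the ethyl and 4-(trifluoromethyl)benzyl compounds. No measurement offered here accounts for these steps.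

The carbonyl and the 3-hydroxypiperidin-1-yl ring enter together, which leaves open which of them carries the step. A plain acetyl on this nitrogen, or a piperidin-1-yl without the hydroxyl on the same carbonyl chain, would separate the two.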